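This account rests on a few compounds, and the source may have more. Where it says the series, first, only, none or still open, it means among the compounds named here.

In a functional assay on KB cells (Homo sapiens) for antiproliferative activity, read by sulforhodamine B assay, with a stated time of 3 days (on this read-out higher numbers stand for an effect only at larger amounts of compound and lower numbers for an effect already at smaller amounts), three compounds sharing one core have been tested so far. Compound 1 `CCCc1ccc(-c2cc(=O)c3c(o2)C(CC)(CC)C(=O)C(CC)=C3O)cc1` gives only a limit, > 53 uM. Compound 2 `CCC1=C(O)c2c(oc(-c3ccc(Br)cc3)cc2=O)C(CC)(CC)C1=O` also gives only a limit, > 48.1 uM. Compound 3 `CCC1=C(O)c2c(oc(-c3ccccc3C)cc2=O)C(CC)(CC)C1=O`, at 40.9 uM, is the only one of the three with an actual number.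

Compound 4 `CCC1=C(O)c2c(oc(-c3ccc(C)cc3C)cc2=O)C(CC)(CC)C1=O` departs from compound 3 by one change: methyl in place of hydrogen on an aromatic carbon. In words, this is methyl in place of hydrogen on an aromatic carbon, or 2-methylphenyl to 2,4-dimethylphenyl. For the measured compounds named here, no measured step adds this methyl directly, so the closest evidence comes from other changes on the aromatic group. The data show an at least 1.2-fold lower number from compound 1 to compound 3 (0.11 log units; that floor lies within the scatter), and also an at least 1.1-fold lower number from compound 2 to compound 3 (0.07 log units; that floor lies within the scatter). The remaining comparison is a step that the two limits leave unreadable from compound 1 to compound 2. None of these gives a readable step beyond the scatter, so no step beyond the scatter is expected in this assay, in either direction. The expected change is a 1.0-fold higher number from compound 3 to compound 4 (0.01 log units; within the scatter). Compound 4 is estimated at 42 uM, within an expected range of 22 uM to 65 uM.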

Compound 4, concentration for half-maximal effect: 41.2 uM
Estimate against measurement, compound 4: 1.0-fold (0.01 log units) above; the range from low to high includes it.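

Methyl on this aromatic carbon, meta to a methyl group and para to a large group, gives the first direct reading at this position, a 1.0-fold higher number from compound 3 to compound 4 (0.00 log units; within the scatter), so 2,4-dimethylphenyl and 2-methylphenyl cannot be told apart on this read-out. The comparisons with the two compounds that stand at limits give an at least 1.1-fold lower number from compound 2 to compound 4 (0.06 log units; that floor lies within the scatter) and an at least 1.2-fold lower number from compound 1 to compound 4 (0.10 log units; that floor lies within the scatter), and both are floors, so neither shows a step beyond the scatter. Nothing given here accounts for the methyl making no readable difference.

As far as these compounds go, it stays open whether an amine, a carboxylic acid or a longer chain such as propyl on this same carbon, with the 2-methyl kept, would move the number beyond the scatter. Also open, from the compounds shown here alone, is whether any group here could bring the number down to much smaller amounts of compound.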